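A few compounds are considered here, and "the series" means these few. Any claim that something is new, unique, unknown or untested is made for them only; others in the source may bear on it.

Among the compounds with values here, compound 2 `CCc1ccc(C(=O)NC[C@H]2c3[nH]c4ccccc4c3C[C@H]3[C@H]4c5[nH]c6ccccc6c5C[C@@H]([C@H](C#N)N23)N4C)cc1` gives, in a functional assay on BGC-823 cells (Homo sapiens) for cytotoxicity, read by MTT assay, with a stated time of 72 h (a lower number here means a stronger inhibitor, a higher number a weaker inhibitor), the higher of the two numbers measured so far: compound 2 gives 660 nM, whereas compound 1 `CN1[C@@H]2c3[nH]c4ccccc4c3C[C@H]1[C@H](C#N)N1[C@@H](CNC(=O)c3ccc(Cl)cc3)c3[nH]c4ccccc4c3C[C@@H]21` gives 110 nM. Within the data shown here, the single measured step, a 6.0-fold higher number from compound 1 to compound 2 (0.78 log units; beyond the scatter), swapped one small substituent on an aromatic carbon. Among the measured compounds shown here, compound 3 `CN1[C@@H]2c3[nH]c4ccccc4c3C[C@H]1[C@H](C#N)N1[C@@H](CNC(=O)c3cc4ccccc4o3)c3[nH]c4ccccc4c3C[C@@H]21` differs from compound 2 by 1-benzofuran-2-yl in place of 4-ethylphenyl on a carbonyl carbon, a change of the whole aromatic group rather than of one substituent, and no measured step covers such a swap. The estimate therefore leans only loosely on a 6.0-fold higher number from compound 1 to compound 2 (0.78 log units; beyond the scatter). Compound 3 is expected at 300 nM, within 80 nM to 1200 nM, which means an expected 2.2-fold lower number from compound 2 to compound 3 (0.34 log units; beyond the scatter).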

Compound 3, half-maximal inhibitory concentration: 210 nM
For compound 3 the middle estimate is 1.4-fold (0.15 log units) above the measured one, within the range that was stated.
By their numbers in this assay, from the lowest: compounds 1 and 3 (each within the scatter of the next); then compound 2.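

In this assay the whole aromatic group on the carbonyl carbon can be exchanged, not just one substituent: 1-benzofuran-2-yl in place of 4-ethylphenyl gives a 3.1-fold lower number from compound 2 to compound 3 (0.50 log units; beyond the scatter). Set against 4-chlorophenyl, the same group gives a 1.9-fold higher number from compound 1 to compound 3 (0.28 log units; within the scatter), so those two cannot be told apart here, and 4-ethylphenyl alone stands apart from both. Nothing available explains these differences.

The compounds shown leave open how this position responds to a group without an aromatic ring, such as cyclohexyl or a longer alkyl chain, or to one carrying an amine.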